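The source may hold more compounds than are shown below. What is called first, only, known or untested is meant among the compounds shown, and "the series" means these compounds.

Working notes on the series, read in a toxicity assay on the whole organism (J774 cells) for cytotoxicity, with Mus musculus as the target, read by MTT assay, with a stated time of 24 h, tested at 10 uM; a higher number here means a weaker effect of the compound at the concentration tested, a lower number a stronger effect.

Compound 1, `CCCCCCCCCO[C@@H]1[C@@H](N)[C@@H](OCC(O)CNCCCO)O[C@H](CN)[C@H]1OCCCCCCCCC`, gives 89.9%. Compound 2, `CCCCCCCCCO[C@@H]1[C@@H](N)[C@@H](O[C@H]2[C@H](O)[C@@H](OCCCCCCCCC)[C@H](N)C[C@@H]2N)O[C@H](CN)[C@H]1O`, gives 78.4%, and compound 3, `C=CCO[C@H]1O[C@H](CN)[C@@H](O)[C@H](O)[C@H]1N`, gives 82.2%. Among these three, compound 1 and compound 3 stand within the usual scatter of each other, so no order between them can be read. Compound 2 stands beyond the scatter below compound 1; this is the only gap among the three measured compounds that exceeds the scatter. Within the data shown here, no two of the measured compounds differ in one place only, so no single step has yet been measured in this assay.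

Compound 4, `CCCCCCCCCO[C@@H]1[C@@H](N)[C@@H](OCC(O)CNCCO)O[C@H](CN)[C@H]1OCCCCCCCCC`, is the next compound to be read in this assay. Against compound 1 the change is hydroxy in place of hydroxymethyl on a saturated chain carbon, two bonds along the chain from an amine nitrogen. The rest of compound 1 is left untouched. Among the measured compounds shown here, with no measured step to lean on, the change is taken as a small one, and the step of a number 1.9 percentage points lower from compound 1 to compound 4 (within the scatter) is expected to stay within the scatter, with no direction beyond it. Compound 4 is therefore expected to give 88%, with a range from 76% to 98%.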

Compound 4, a percentage reported as activity, at one concentration (the size of the read-out at that concentration, not a potency): 99.1%
Compound 4: middle estimate off by 11.1 percentage points, on the low side; the whole stated range lies below it.
By their numbers in this assay, from the lowest: compounds 2, 3, 1 and 4 (each within the scatter of the next, the first and the last beyond it).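

Among these compounds, this is the first single step measured: in this assay, hydroxy in place of hydroxymethyl on a saturated chain carbon, two bonds along the chain from an amine nitrogen, gives a number 9.2 percentage points higher from compound 1 to compound 4 (within the scatter) and so stays inside the usual scatter. At this position, then, the (3-hydroxypropyl)amino and (2-hydroxyethyl)amino chains cannot be told apart in this read-out, with the rest of the structure held the same, and the step gives no direction. No measurement is at hand that bears on what lies behind this step.

The compounds shown leave open whether a longer chain such as 4-hydroxybutyl, or an amine or a carboxylic acid in place of the hydroxy at the chain end, would also stay within the scatter of compound 1. They also leave open whether the same step would read alike on the structures of compound 2 or compound 3, as each differs from compound 1 in more than one place.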